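Replacing methoxy with trifluoromethyl in compound 3

The compounds below may be only part of what the source reports. "The series", "measured", "known", "first", "only" and "open" are said of these compounds alone.

Measured so far in a functional assay on HL-60 cells (Homo sapiens) for cytotoxicity, read by WST assay, with a stated time of 48 h (a higher number here means that more compound is needed for the effect, a lower number that less compound is needed), are three compounds
Compound 1 `O=C1OC[C@H](Cc2ccccc2)[C@H]1Cc1ccccc1O` gives 83000 nM
Compound 2 `CCCCOc1ccccc1C[C@H]1C(=O)OC[C@@H]1Cc1ccccc1` gives 20000 nM
Compound 3 `COc1ccc(C[C@H]2C(=O)OC[C@@H]2Cc2ccccc2)cc1` gives 67000 nM

Compound 3 (67000 nM) stands at the high end of these numbers together with compound 1 (83000 nM), and the two lie within the usual scatter of each other. Compound 2 (20000 nM) shows a clearly lower number than either.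

The next molecule is compound 4 `O=C1OC[C@H](Cc2ccccc2)[C@H]1Cc1ccc(C(F)(F)F)cc1` which keeps the shared core of compound 3 and carries trifluoromethyl in place of methoxy on an aromatic carbon, para to a large group (trifluoromethyl in place of methoxy on an aromatic carbon).

Going by the values given here, only one measured step exists to guide an expectation. It is a 4.2-fold lower number from compound 1 to compound 2 (0.62 log units; beyond the scatter) and it puts butyl in place of hydrogen on an oxygen on an aromatic ring. That is a different change from the one at hand, so it gives only a rough idea of size. Among the compounds with values here, no measured pair swaps methoxy or introduces trifluoromethyl, which leaves the direction poorly supported. A small move toward a lower number seems the most reasonable guess, with no change beyond the scatter also quite possible. The step expected in this assay is a 1.5-fold lower number from compound 3 to compound 4 (0.17 log units; within the scatter) and no larger shift is foreseen. Compound 4 is estimated at 45000 nM (expected range 18000 nM to 100000 nM).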

Compound 4, half-maximal effective concentration: 22000 nM
Estimate against measurement, compound 4: 2.0-fold (0.31 log units) above, and the stated range covers the measured number.
By their numbers in this assay, from the lowest: compounds 2 and 4 (each within the scatter of the next); then compounds 3 and 1 (each within the scatter of the next).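

In this assay the aromatic carbon para to a large group, which holds methoxy in compound 3, proves sensitive to the group placed on it: putting trifluoromethyl there gives a 3.0-fold lower number from compound 3 to compound 4 (0.48 log units; beyond the scatter). Going by these compounds alone, the one earlier step, a 4.2-fold lower number from compound 1 to compound 2 (0.62 log units; beyond the scatter), changed a group on an oxygen on an aromatic ring, so this new result adds a second change beyond the scatter, this time at a ring carbon and with a group that has no oxygen and no hydrogen-bond acceptor by the count. No measurement at hand accounts for the shift, which therefore stands as an observation without an explanation.

The compounds shown leave open whether the lower number comes with the loss of methoxy or with trifluoromethyl itself, a question that a plain methyl, a chlorine or a nitrile on the same carbon could help to settle. Also open, on these data alone, is how an amine, a carboxylic acid or a longer chain on that carbon would fare, and whether the same swap on the other aromatic ring would move the number at all.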